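From 2-chlorobenzyl to 2,4-dichlorobenzyl: compound 3 to compound 4

This account rests on a few compounds, and the source may have more. Where it says the series, first, only, none or still open, it means among the compounds named here.

Values in a functional assay on A549 cells (Homo sapiens) for antiproliferative activity, read by MTT assay, with a stated time of 48 h (a higher number here means a weaker inhibitor, a lower number a stronger inhibitor), so far

Compound 1 `O=[N+]([O-])c1cc(C(F)(F)F)cc([N+](=O)[O-])c1Oc1ccccc1/C=N\OCc1ccccc1` gives 1470 nM
Compound 2 `O=[N+]([O-])c1cc(C(F)(F)F)cc([N+](=O)[O-])c1Oc1ccccc1/C=N\OCc1ccccc1F` gives 860 nM
Compound 3 `O=[N+]([O-])c1cc(C(F)(F)F)cc([N+](=O)[O-])c1Oc1ccccc1/C=N/OCc1ccccc1Cl` gives 1430 nM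

Compound 3 lies within the scatter of the other two, as (a 1.0-fold lower number from compound 1 to compound 3 (0.01 log units; within the scatter)) and (a 1.7-fold higher number from compound 2 to compound 3 (0.22 log units; within the scatter)) show. Compound 4 `O=[N+]([O-])c1cc(C(F)(F)F)cc([N+](=O)[O-])c1Oc1ccccc1/C=N/OCc1ccc(Cl)cc1Cl` differs from it by chloro in place of hydrogen on an aromatic carbon, a chloro in place of hydrogen on an aromatic carbon, para to a large group. Among the measured compounds shown here, the only related evidence is those two steps and (a 1.7-fold lower number from compound 1 to compound 2 (0.23 log units; within the scatter)), all halogen changes within the scatter. For the measured compounds named here, no measured step adds a group at this place. No step beyond the scatter is therefore expected in this assay. The estimated step is small (a 1.2-fold lower number from compound 3 to compound 4 (0.09 log units; within the scatter)). For compound 4 the expected value is 1150 nM, with an estimated range from 480 nM to 2700 nM.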

Compound 4, half-maximal inhibitory concentration: 1610 nM
For compound 4 the middle estimate is 1.4-fold (0.15 log units) below the measured one; low and high end bracket the measured number.
By their numbers in this assay, from the lowest: compounds 2, 3, 1 and 4 (each within the scatter of the next).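

Chloro in place of hydrogen, para to a large group, gives a 1.1-fold higher number from compound 3 to compound 4 (0.05 log units; within the scatter) in this assay, the only step shown that adds a group at this place. The 2,4-dichlorobenzyl of compound 4 thus stays within the scatter of the 2-chlorobenzyl of compound 3, so a second chloro here brings no measurable change. No measurement at hand bears on this result. The compounds shown leave open whether a different group at this place, such as an amine, a methoxy group or a carboxylic acid, would give a step beyond the scatter.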